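Halogen exchange on the amide-bound phenyl ring

The source may report more compounds than this note shows. Statements on the series, on what has been measured and on what is new or still open speak of the compounds shown alone.

Compound 1 `O=C(CSc1nc(Nc2ccccc2)c2ccccc2n1)Nc1cccc(F)c1` and compound 2 `O=C(CSc1nc(Nc2ccccc2)c2ccccc2n1)Nc1cccc(Cl)c1` share one core and differ only at the amide-bound phenyl ring. In a functional assay on MGC-803 cells (Homo sapiens) for inhibition, read by MTT assay, with a stated time of 72 h (a higher number here means a weaker inhibitor, a lower number a stronger inhibitor), compound 1 gives 12700 nM, and compound 2 gives 14300 nM. The step of a 1.1-fold lower number from compound 2 to compound 1 (0.05 log units; within the scatter) corresponds to fluoro in place of chloro on an aromatic carbon. Compound 3 `O=C(CSc1nc(Nc2ccccc2)c2ccccc2n1)Nc1ccc(Cl)c(Cl)c1` gives 37900 nM in this assay, the highest number among the three measured compounds; its steps are a 2.7-fold higher number from compound 2 to compound 3 (0.42 log units; beyond the scatter) and a 3.0-fold higher number from compound 1 to compound 3 (0.47 log units; beyond the scatter).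

Compound 4 `O=C(CSc1nc(Nc2ccccc2)c2ccccc2n1)Nc1ccc(F)c(Cl)c1` has not yet been measured in this assay. It differs from compound 3 by fluoro in place of chloro on an aromatic carbon. This is the same kind of change as that from compound 2 to compound 1, but not the same: there the place was meta to a large group, here it is ortho to a chloro group and para to a large group. The two cores on which the change is made differ by chloro in place of hydrogen on an aromatic carbon.

Since the earlier step of a 1.1-fold lower number from compound 2 to compound 1 (0.05 log units; within the scatter) lies within the scatter, a similarly small step from compound 3 to compound 4 is expected, a 1.1-fold lower number from compound 3 to compound 4 (0.05 log units; within the scatter). Compound 4 is therefore estimated at 34000 nM, expected to fall between 17000 nM and 68000 nM.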

Compound 4, half-maximal inhibitory concentration: 20900 nM
Compound 4: middle estimate off by 1.6-fold (0.21 log units), on the high side, and the stated range covers the measured number.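

In this assay the exchange of chloro for fluoro on an aromatic carbon reads alike on the two cores, with no difference resolved between them: the same change on two cores in this assay, a 1.1-fold lower number (0.05 log units; within the scatter) from compound 2 to compound 1 and a 1.8-fold lower number (0.26 log units; within the scatter) from compound 3 to compound 4, 1.6-fold (0.21 log units) apart, within the scatter of two such steps. The new steps of a 1.8-fold lower number from compound 3 to compound 4 (0.26 log units; within the scatter) and a 1.5-fold higher number from compound 2 to compound 4 (0.16 log units; within the scatter) and a 1.6-fold higher number from compound 1 to compound 4 (0.22 log units; within the scatter) all lie within the scatter, so compound 4 cannot be ordered against compound 1, compound 2 or compound 3. This rests on two pairs in a single assay, so it shows that the change carried across these two cores without a resolved difference, but it does not show that the exchange has no effect or that it would read the same on other cores.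

Only halogens on the amide-bound phenyl ring vary here, and the rest of the shared core stays fixed. From the compounds shown here alone, whether the exchange reads the same on a ring that also bears a methoxy group, or with a longer chain linking the sulfur to the carbonyl, remains open.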